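Swapping a Thiophene for a Pyridine on the Shared Core

The source may hold more compounds than are shown below. What is called first, only, known or untested is meant among the compounds shown, and "the series" means these compounds.

Compound 1 `Oc1cccc(-c2cc(-c3ccc(Cl)cc3)nc(-c3cccs3)c2)c1` is one of three compounds tested in a functional assay on HCT-15 cells (Homo sapiens) for cytotoxicity, read by CCK-8 assay and cell counting, with a stated time of 2 days (on this read-out lower numbers stand for stronger inhibition and higher numbers for weaker inhibition), where compound 1 gives 9280 nM. Compound 2 `Oc1cccc(-c2cc(-c3cccc(Cl)c3)nc(-c3cccs3)c2)c1` gives 2610 nM in this assay, and compound 3 `Oc1ccc(-c2cc(-c3cccnc3)nc(-c3cccc(Cl)c3)c2)cc1` gives 21300 nM. Compound 1 thus stands second highest of the three numbers: compound 3 sits above it, while compound 2 lies furthest from it on the low side. The one single-point step among these compounds runs a 3.6-fold lower number from compound 1 to compound 2 (0.55 log units; beyond the scatter), a change at the chlorophenyl group rather than at the group that is varied here.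

Compound 4 `Oc1cccc(-c2cc(-c3ccncc3)nc(-c3ccc(Cl)cc3)c2)c1` differs from compound 1 in one place: pyridin-4-yl in place of thiophen-2-yl on an aromatic carbon. Going by the values given here, no measured step covers this swap directly. Among the compounds with values here, the only guidance is indirect: compound 3, which also carries a pyridine in place of the thiophene, gives the highest number of the set, but it differs from compound 1 in several places, so its value cannot be read as a clean step. He therefore expects at most a modest move, tending toward a higher number, and estimates the step to be a 1.5-fold higher number from compound 1 to compound 4 (0.18 log units; within the scatter). For compound 4 in this assay he estimates 14000 nM, with a range from 5000 nM to 40000 nM.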

Compound 4, half-maximal inhibitory concentration: 2630 nM
Compound 4: the middle estimate sits 5.3-fold (0.73 log units) above what was measured; measured number below the stated range.
By their numbers in this assay, from the lowest: compounds 2 and 4 (each within the scatter of the next); then compound 1; then compound 3.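

In this assay, pyridin-4-yl in place of thiophen-2-yl on this aromatic carbon brings a 3.5-fold lower number from compound 1 to compound 4 (0.55 log units; beyond the scatter), so the larger six-membered ring is compatible with a lower number than the thiophene gives here. Going by these compounds alone, this is the first single-place step measured at this carbon, as the earlier step lay at the chlorophenyl group and said nothing directly about the group changed here. The swap changes ring size and exchanges sulfur for nitrogen while the hydrogen-bond donor and acceptor counts stay the same, and nothing available here explains why the number moves.

Within the data shown here, the single step cannot separate the change in ring size from the change in hetero atom, and a plain phenyl ring on the same carbon would be needed to start telling them apart. The compounds shown also leave open whether the same swap gives a similar step with the 3-chlorophenyl group of compound 2, and how a pyridine bearing an amine or a carboxylic acid would read at this carbon.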